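This account rests on a few compounds, and the source may have more. Where it says the series, first, only, none or still open, it means among the compounds named here.

Working notes on the series.

In an ADME assay on liver for metabolic stability, with Liver microsome (Homo sapiens) as the target, read by LC-MS, using microsomes, with a stated time of 5 h (on this read-out higher numbers stand for fast clearance and lower numbers for slow clearance), compound 1 `C[C@@]1(c2ccc(OC(F)(F)F)cc2)C[C@@](O)(c2ccccn2)CO1` gives 66.7 mL/min/kg. Compound 2 `O[C@]1(c2ccccn2)CC[C@H](c2ccc(C(F)(F)F)cc2)C1` gives 333 mL/min/kg in this assay, and compound 3 `C[C@]1(O)C[C@](c2cc(C(F)(F)F)ccn2)([C@H](O)c2ccccn2)C1` gives 33.3 mL/min/kg. Among the measured compounds shown here, of the three numbers measured so far, compound 1 holds the second highest; its gap to compound 3 is within the scatter of this assay, so the two are not separated, while compound 2 sits beyond the scatter from compound 1 and is the only one of the three that is clearly set apart.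

Compound 4 `C[C@@]1(c2ccc(OC(F)(F)F)cc2)C[C@](O)(c2ccccn2)CO1` is the next compound to be measured in this assay. Relative to compound 1 the structure changes as follows: the two compounds have the same atoms and bonds and differ only in configuration as drawn: 1 of 2 stereo elements differ; a stereocentre at a saturated ring carbon is drawn R in compound 1 and S in compound 4. Nothing leaves and nothing enters; the same atoms and bonds are present, and only the configuration drawn at one saturated ring carbon differs.

For the measured compounds named here, no step between two measured compounds of this kind is available in this assay, and none of the measured pairs differs in one place, so the series gives no direct precedent for the inversion. On that basis the step from compound 1 to compound 4 is expected to be small, without a preferred direction, and to stay within the scatter: a 1.0-fold higher number from compound 1 to compound 4 (0.00 log units; within the scatter). Compound 4 is accordingly estimated at 67 mL/min/kg, with a range from 30 mL/min/kg to 150 mL/min/kg.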

Compound 4, clearance: 217 mL/min/kg
Beside the measured number, compound 4's estimate is 3.2-fold (0.51 log units) below it; the whole stated range lies below it.
By their numbers in this assay, from the lowest: compounds 3 and 1 (each within the scatter of the next); then compounds 4 and 2 (each within the scatter of the next).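

In this assay the inversion gives a 3.3-fold higher number from compound 1 to compound 4 (0.51 log units; beyond the scatter), so the configuration drawn at this saturated ring carbon is not neutral for clearance, which compounds 1, 2 and 3 could not show because no two of them differ in one place only. Among the compounds shown here, this is the first single-change pair, and it shows that a read-out on this core can move beyond the usual scatter with no atom or bond gained or lost, so stereochemistry at this centre has to be specified when clearance values are compared here. The step can be assigned to the inverted centre alone, because nothing else separates the pair: the fact that compounds 1 and 4 differ only in the configuration as drawn.

For the compounds shown here, the pair gives one step at one centre on one core, so it remains open whether inverting the second stereo element would move clearance in the same direction or by a similar size, and whether the R form stays the one with the lower number on other cores. Going by these compounds, it is equally open whether the step would persist if an amine or a carboxylic acid were carried on the core of compound 1, and the pair says nothing about why the two forms differ.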